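This account rests on a few compounds, and the source may have more. Where it says the series, first, only, none or still open, it means among the compounds named here.

Measured compounds in the series, cytotoxicity read-out:

Compound 1, `Cc1cc(NC(=O)Nc2cc(F)ccc2F)c2ccccc2n1`. In an ADME assay on Raji cells (Homo sapiens) for cytotoxicity, with a stated time of 72 h (on this read-out lower numbers stand for an effect already at smaller amounts and higher numbers for an effect only at larger amounts of compound), compound 1 gives only a limit, > 25000 nM.
Compound 2, `Cc1cc(NC(=O)Nc2cccc([N+](=O)[O-])c2)c2ccccc2n1`. In this assay compound 2 likewise gives only a limit, > 25000 nM.
Compound 3, `COc1cccc(NC(=O)Nc2cc(C)nc3ccccc23)c1`. In this assay compound 3 again gives only a limit, > 25000 nM.

Compound 3 therefore stands at the same limit as the other two; no number is known for any of them, and every value shown sits at the limit of > 25000 nM in this assay, at which 3 of the 3 values shown sit. For the measured compounds named here, the one single-point step in the set, a step that the two limits leave unreadable from compound 2 to compound 3, is unreadable, since both ends are limits.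

The next compound, compound 4, is `Cc1cc(NC(=O)Nc2cccc(F)c2)c2ccccc2n1`. It differs from compound 3 by fluoro in place of methoxy on an aromatic carbon. Going by the values given here, no measured step bears on this change with a readable size: the only step between neighbours is the unreadable one from compound 2 to compound 3, and the two other values are limits as well. With three of three values at the limit, nothing in the data points to a step in either direction beyond the scatter; the expectation is that compound 4 will also report a limit rather than a number.

The step expected from compound 3 to compound 4 is accordingly a step that the limit leaves unreadable from compound 3 to compound 4, i.e. no readable change. For compound 4 the estimate is 40000 nM, with a range from 12000 nM to 150000 nM.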

Compound 4, half-maximal effective concentration: > 25000 nM
Compound 4 ended at the assay's limit; the forecaster's own chance of this, stated with the estimate: 85%; the middle value lies beyond the limit too.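

Compound 4 gives only a limit in this assay, and the steps linking it to compound 1, compound 2 and compound 3 therefore cannot be read, with every value at the same limit: the limit of > 25000 nM in this assay, at which 4 of the 4 values shown sit.

The compounds shown leave open whether the fluoro, methoxy and nitro groups differ at all in this assay.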